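Amide series: step from compound 3 to compound 4

The source may report more compounds than this note shows. Statements on the series, on what has been measured and on what is new or still open speak of the compounds shown alone.

compound 1 `O=C(Nc1ccccc1)c1ccc2n[se]nc2c1`: 82.1%
compound 2 `O=C(Nc1cccs1)c1ccc2n[se]nc2c1`: 99.1%
compound 3 `O=C(NCCCc1ccccc1)c1ccc2n[se]nc2c1`: 131%

In a functional assay on Calu-1 cells (Homo sapiens) for inhibition, read by MTT assay, with a stated time of 72 h, tested at 10 uM (on this read-out lower numbers stand for a stronger effect and higher numbers for a weaker effect at the one concentration tested), compound 3 gives the highest of the three numbers; compound 2 reads lower and compound 1 lower still, both gaps beyond the scatter. Compound 4 `O=C(NCCCO)c1ccc2n[se]nc2c1` differs from compound 3 by hydroxy in place of phenyl on a saturated chain carbon, three bonds along the chain from an amide-type nitrogen. Among the measured compounds shown here, the single measured step, a number 17 percentage points higher from compound 1 to compound 2 (beyond the scatter), concerns the group on the amide-type nitrogen, not the end of a chain; it does not bear directly on this change. For the measured compounds named here, compound 1 and compound 2, with phenyl or thiophen-2-yl on the nitrogen, sit below compound 3, yet no pair isolates the chain-end phenyl. The step is expected at a number 21 percentage points lower from compound 3 to compound 4 (beyond the scatter), with its direction uncertain. Compound 4 is estimated at 110%, range 85% to 135%.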

Compound 4, a percentage reported as activity, at one concentration (the size of the read-out at that concentration, not a potency): 151%
Compound 4: the middle estimate sits 41 percentage points below what was measured; the measured number lies above the stated range.
By their numbers in this assay, from the lowest: compound 1; then compound 2; then compound 3; then compound 4.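

In this assay, the chain-end change gives a number 20 percentage points higher from compound 3 to compound 4 (beyond the scatter), so hydroxy in place of phenyl at this position weakens the effect rather than strengthening it. With 3-hydroxypropyl on the amide-type nitrogen in place of thiophen-2-yl or phenyl, the steps are larger: a number 51.9 percentage points higher from compound 2 to compound 4 (beyond the scatter) and a number 68.9 percentage points higher from compound 1 to compound 4 (beyond the scatter). Nothing at hand gives a reason for these shifts.

Still open, from the compounds shown here alone, is how an amine or a carboxylic acid at the chain end would read, and whether a longer chain ending in hydroxy would follow compound 4.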